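A few compounds are considered here, and "the series" means these few. Any claim that something is new, unique, unknown or untested is made for them only; others in the source may bear on it.

In a functional assay on RAW264.7 cells (Mus musculus) for inhibition, read by Griess assay, with stated times of 2 h and 18 h (on this read-out lower numbers stand for stronger inhibition and higher numbers for weaker inhibition), compound 2 `CC1=CC[C@@H]2[C@](C)(CCC[C@]2(C)C=O)[C@H]1CC/C(C)=C/CO` gives 29000 nM. Going by the values given here, this is the only actual number available so far, which leaves compound 2 as the single fixed point on the scale. The other result comes from compound 1 `CC1=C(CCC2=CCOC2=O)[C@@]2(C)CC[C@@H](O)C(C)(C)C2=C(O)C1=O`, on a different core. Compound 1 reads > 50000 nM in this assay, and this value is a limit of the assay and not a number.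

The next compound to be tested is compound 3 `CC1=CC[C@H]2[C@@](C)(CO)CCC[C@]2(C)[C@H]1CC/C(C)=C/CO`. It differs from compound 2 in one place, with hydroxymethyl in place of formyl on a saturated ring carbon of a six-membered non-aromatic ring of carbon only (hydroxymethyl in place of formyl on a saturated ring carbon). Among the compounds with values here, no measured pair of compounds shows what a change of this kind does in this assay, so the expectation rests on the value of compound 2 at 29000 nM and on how limited the change is. A small shift towards weaker inhibition is expected, perhaps no larger than the usual scatter. The expected change is a 1.2-fold higher number from compound 2 to compound 3 (0.08 log units; within the scatter). For compound 3 the estimated value is 35000 nM, within an expected range of 15000 nM to 80000 nM.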

Compound 3, half-maximal inhibitory concentration: 33400 nM
Compound 3: the middle estimate sits 1.0-fold (0.02 log units) above what was measured; the measured number falls inside the stated range.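

Going by these compounds alone, the first step that can be read in this assay is hydroxymethyl in place of formyl on a saturated ring carbon, and it gives a 1.2-fold higher number from compound 2 to compound 3 (0.06 log units; within the scatter). At this position, which is part of a fused or bridged system of two rings, a group with no hydrogen-bond donor can thus give way to one with a hydrogen-bond donor, at the same count of heavy atoms, without the read-out leaving the scatter, so this pair cannot be put in order of strength. The scale also leaves limited room for any weakening from this level, since compound 1 stands at a limit of the assay and not at a number: the limit of > 50000 nM in this assay, at which 1 of the 3 values shown sits.

What the compounds shown leave open is whether a carboxylic acid, a methyl ester or an amine on the same ring carbon would move the number beyond the scatter in either direction. Going by these compounds, it also remains open whether any change at this carbon could bring inhibition into a much lower range, and whether the side chain ending in hydroxymethyl matters to the read-out at all.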